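The source may hold more compounds than are shown below. What is called first, only, known or untested is meant among the compounds shown, and "the series" means these compounds.

In a functional assay on MCF7 cells (Homo sapiens) for cytotoxicity, read by MTT assay, with a stated time of 72 h (on this read-out higher numbers stand for weaker inhibition and lower numbers for stronger inhibition), compound 1 `CC(C)=C1C(=O)N(c2ccc(Cl)cc2)N(c2ccc(Cl)cc2)C1=O` gives 39600 nM and compound 2 `O=C1C(=Cc2ccc(F)cc2)C(=O)N(c2ccc(Cl)cc2)N1c1ccc(Cl)cc1` gives 31400 nM, two numbers within the scatter of each other. Compound 3 `COc1cc(C=C2C(=O)N(c3ccc(Cl)cc3)N(c3ccc(Cl)cc3)C2=O)ccc1O` differs from compound 2 in one place: 4-hydroxy-3-methoxyphenyl in place of 4-fluorophenyl on a double-bonded chain carbon bound to a double-bonded ring carbon, with 4-hydroxy-3-methoxyphenyl in place of 4-fluorophenyl on a double-bonded chain carbon bound to a double-bonded ring carbon. For the measured compounds named here, no measured pair yet shows the effect of a change at this place. A small expected step toward stronger inhibition is the working assumption, a 1.7-fold lower number from compound 2 to compound 3 (0.24 log units; within the scatter). The estimated value for compound 3 is 18000 nM, with an expected range of 6000 nM to 50000 nM.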

Compound 3, half-maximal inhibitory concentration: 22800 nM
For compound 3 the middle estimate is 1.3-fold (0.10 log units) below the measured one; the measured number falls inside the stated range.
By their numbers in this assay, from the lowest: compounds 3, 2 and 1 (each within the scatter of the next).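

In this assay, the place on a double-bonded chain carbon bound to a double-bonded ring carbon now has its first reading: 4-hydroxy-3-methoxyphenyl in place of 4-fluorophenyl gives a 1.4-fold lower number from compound 2 to compound 3 (0.14 log units; within the scatter) at this place. This exchange brings in a hydrogen-bond donor and hydrogen-bond acceptors, yet the step stays within the scatter. No available measurement bears on the reason for this result.

Still open, from the compounds shown here alone, is how a group carrying an amine or a carboxylic acid would read at this place, and whether hydroxy or methoxy alone would read like the pair.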